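The compounds below may be only part of what the source reports. "The series", "measured", "known", "first", "only" and "open" are said of these compounds alone.

Measured in an assay on V79MZh cells for inhibition of cytochrome P450 11B2, mitochondrial (Homo sapiens), with a stated time of 30 min; on this read-out higher numbers stand for weaker inhibition and lower numbers for stronger inhibition:
Compound 1 `O=c1cc(Cc2ccncc2)oc2ccccc12`, 1240 nM
Compound 2 `O=c1cc(Cc2ccncc2)oc2cc(F)ccc12`, 643 nM
Compound 3 `O=c1c(Cc2cccnc2)coc2ccccc12`, a limit only: > 10000 nM

Compound 1 and compound 2 share one core and differ by fluoro in place of hydrogen on an aromatic carbon. In this assay this step gave a 1.9-fold lower number from compound 1 to compound 2 (0.29 log units; within the scatter). Compound 3 is built on a different core, and the difference between the two cores is not broken down here. For compound 3 this assay reports only a limit, > 10000 nM, which is the limit of > 10000 nM in this assay, at which 1 of the 3 values shown sits. Compound 4 `O=c1c(Cc2cccnc2)coc2cc(F)ccc12` has not yet been measured; it stands to compound 3 as compound 2 stands to compound 1, differing by fluoro in place of hydrogen on an aromatic carbon, the same change at the same kind of place. On the core of compound 1 that change stayed within the scatter, and compound 3 itself gave no number in this assay. The step expected here is therefore small and uncertain, a step that the limit leaves unreadable from compound 3 to compound 4, since the same change earlier gave a 1.9-fold lower number from compound 1 to compound 2 (0.29 log units; within the scatter). Compound 4 is expected to give about 12000 nM in this assay, between 5000 nM and 30000 nM, with a fair chance that only a limit is reported again.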

Compound 4, half-maximal inhibitory concentration: > 10000 nM
Compound 4 was reported as a limit; the forecaster's own chance of this, stated with the estimate: 65%; the middle value does not contradict the limit.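

In this assay compound 3 and compound 4 both report a limit and not a number, so no step between them can be read: the limit of > 10000 nM in this assay, at which 2 of the 4 values shown sit.

The compounds shown leave open whether fluoro in place of hydrogen on an aromatic carbon changes the read-out at all on the core of compound 3.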